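Chloro on the sulfonyl ring: a note on compound 4

The compounds below may be only part of what the source reports. "The series", "measured", "known", "first", "only" and "open" are said of these compounds alone.

Measured compounds:
Compound 1, `Cn1cc(NC(=O)c2ccc(NS(=O)(=O)c3ccccc3)cc2)cn1`; in a functional assay on A549 cells (Homo sapiens) for inhibition, read by MTT assay, with a stated time of 48 h (a higher number here means a weaker inhibitor, a lower number a stronger inhibitor), compound 1 gives > 100000 nM, a limit of the assay and not a number.
Compound 2, `Cc1ccc(-n2cc(NC(=O)c3ccc(NS(=O)(=O)c4ccccc4)cc3)cn2)cc1`; compound 2 gives 54700 nM.
Compound 3, `COc1cccc(-n2cc(NC(=O)c3ccc(NS(=O)(=O)c4ccccc4)cc3)cn2)c1`; compound 3 gives > 100000 nM, again a limit of the assay and not a number.

Among the measured compounds shown here, compound 2 holds the only number in the set; the other two values are limits. The steps around it all run over the substituent on the aromatic nitrogen: an at least 1.8-fold lower number from compound 1 to compound 2 (0.26 log units; that floor lies within the scatter), an at least 1.8-fold higher number from compound 2 to compound 3 (0.26 log units; that floor lies within the scatter), and a step that the two limits leave unreadable from compound 1 to compound 3. Compound 4, `Cc1ccc(-n2cc(NC(=O)c3ccc(NS(=O)(=O)c4ccc(Cl)cc4)cc3)cn2)cc1`, differs from compound 2 in another place: chloro in place of hydrogen on an aromatic carbon. For the measured compounds named here, none of the measured steps touches the ring that carries the sulfonyl group, so none bears directly on this change; the two readable steps sit at the edge of the scatter and concern a different part of the molecule. With nothing in the data to push the number either way, the expected step is one of no size beyond the scatter, a 1.2-fold lower number from compound 2 to compound 4 (0.08 log units; within the scatter). Compound 4 is therefore estimated at 45000 nM, with a range from 15000 nM to 100000 nM, and with a real chance that this assay returns only a limit rather than a number.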

Compound 4, half-maximal inhibitory concentration: 22000 nM
Beside the measured number, compound 4's estimate is 2.0-fold (0.31 log units) above it, and the stated range covers the measured number.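

In this assay, the ring that carries the sulfonyl group now has a measured step of its own, with chloro in place of hydrogen on an aromatic carbon, para to a large group: a 2.5-fold lower number from compound 2 to compound 4 (0.40 log units; beyond the scatter). Among the compounds shown here, this modest step is the only one with a number at both ends and the only one printed as beyond the scatter, whereas the earlier steps all concerned the substituent on the aromatic nitrogen and each ran to a limit. The change from phenylsulfonyl to (4-chlorophenyl)sulfonyl therefore gives the clearest reading so far, and the comparison rests on compounds 2 and 4 alone, as the ceiling of the assay leaves few steps with a readable size: the limit of > 100000 nM in this assay, at which 2 of the 4 values shown sit.

Going by these compounds, whether this position favours chloro in particular stays open, since a single group says nothing about how bromo, a nitrile, an amine or a carboxylic acid would behave in the same place. Also open, on these data alone, is whether the chloro step holds with methyl or 3-methoxyphenyl on the aromatic nitrogen.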